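The source may report more compounds than this note shows. Statements on the series, on what has been measured and on what is new or still open speak of the compounds shown alone.

The series shares the core of compound 1, `O=C(Nc1cc(C(F)(F)F)cc(C(F)(F)F)c1)c1cc(F)ccc1O`, an amide bearing a fluoro group; in an assay for inhibition of transmembrane protease serine 4 (Homo sapiens), read by fluorescence (a lower number here means a stronger inhibitor, a higher number a weaker inhibitor), compound 1 gives 29000 nM. Compound 2, `COc1ccc(O)c(C(=O)Nc2cc(C(F)(F)F)cc(C(F)(F)F)c2)c1`, carries a methoxy group in its place, and in this assay compound 2 gives 29000 nM; the step of no change at the digits printed from compound 1 to compound 2 (within the scatter). Compound 3, `N#Cc1ccc(O)c(C(=O)Nc2cc(C(F)(F)F)cc(C(F)(F)F)c2)c1`, carries a cyano group there, and in this assay compound 3 gives 19000 nM. The steps of a 1.5-fold lower number from compound 1 to compound 3 (0.18 log units; within the scatter) and a 1.5-fold lower number from compound 2 to compound 3 (0.18 log units; within the scatter), so compound 3 stands alongside compound 1 and compound 2, with no separation between the three beyond the scatter.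

Compound 4, `NC(=O)c1ccc(O)c(C(=O)Nc2cc(C(F)(F)F)cc(C(F)(F)F)c2)c1`, differs from compound 3 by carbamoyl in place of cyano on an aromatic carbon. All three exchanges at this place bear on the step, and each of them stayed within the scatter, so no movement beyond the scatter is expected in this assay from compound 3 to compound 4 in either direction. Compound 4 is therefore estimated at 22000 nM, with a range from 8000 nM to 60000 nM, corresponding to an expected step of a 1.2-fold higher number from compound 3 to compound 4 (0.06 log units; within the scatter).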

Compound 4, half-maximal inhibitory concentration: > 100000 nM
Compound 4 ended at the assay's limit; the forecaster's own chance of this, stated with the estimate: 20%; middle value at least 4.5-fold (0.65 log units) away from the limit.
By their numbers in this assay, from the lowest: compounds 3, 1 and 2 (each within the scatter of the next). At a limit, above all of these: compound 4.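

Compound 4 reads only as a limit in this assay, not as a number: the limit of > 100000 nM in this assay, at which 1 of the 4 values shown sits. Fluoro, methoxy and cyano on this aromatic carbon, para to a hydroxy group, gave values within the scatter of one another, whereas carbamoyl moves the reading beyond the scatter against all three, with an at least 5.2-fold higher number from compound 3 to compound 4 (0.72 log units; beyond the scatter), an at least 3.4-fold higher number from compound 2 to compound 4 (0.53 log units; beyond the scatter) and an at least 3.4-fold higher number from compound 1 to compound 4 (0.53 log units; beyond the scatter). This position is therefore not indifferent to what it carries, and the exchange shows that at least one group placed there weakens inhibition in this assay.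

The entering carbamoyl has 1 hydrogen-bond donor where cyano has 0, but the compounds shown cannot tell whether this difference accounts for the step. From the compounds shown here alone, it remains open how an amine, a carboxylic acid or an N-methyl carbamoyl at this place would read, and whether any group there could lower the number beyond the scatter.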